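The source may report more compounds than this note shows. Statements on the series, on what has been measured and on what is new or still open speak of the compounds shown alone.

Compound 2, `CC(C)C(Nc1nccs1)c1ccc(-c2ccc3cccc(F)c3c2)[nH]c1=O`, and compound 1, `CC(C)C(c1ccc(-c2ccc3cccc(F)c3c2)[nH]c1=O)N1CCCCC1=O`, share one core and differ only at the saturated chain carbon bound to an aromatic carbon and a saturated chain carbon. In an ADME assay on microsomes from liver (Mus musculus) for metabolic stability (on this read-out lower numbers stand for a shorter-lived compound and higher numbers for a longer-lived compound), compound 1 gives 0.0967 h, and in this assay compound 2 gives 0.0733 h. Among the compounds with values here, the single measured step, a 1.3-fold lower number from compound 1 to compound 2 (0.12 log units; within the scatter), lies within the scatter, so the two numbers cannot be told apart; compound 2 simply stands beside compound 1 at the short-lived end of what has been measured.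

Compound 3, `CC(C)C(CC(N)=O)c1ccc(-c2ccc3cccc(F)c3c2)[nH]c1=O`, carries the change (carbamoylmethyl in place of (1,3-thiazol-2-yl)amino on a saturated chain carbon bound to an aromatic carbon and a saturated chain carbon). Within the data shown here, no measured step involves carbamoylmethyl, so the only guide is the step from compound 1 to compound 2, which replaced one group at the same position without moving the half-life beyond the scatter. On that basis the half-life of compound 3 in this assay is expected to stay close to that of compound 2, with the step of a 1.1-fold higher number from compound 2 to compound 3 (0.04 log units; within the scatter) expected to fall within the scatter. The estimate for compound 3 is therefore 0.08 h, with a range from 0.03 h to 0.2 h.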

Compound 3, half-life: < 0.0667 h
Compound 3 gave a limit, no number (the forecaster's own chance of this, stated with the estimate: 5%); middle value at least 1.1-fold (0.07 log units) away from the limit.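

In this assay, within the data shown here, compound 3 is the only one of the three compounds that reaches a limit of the assay rather than a number: the limit of < 0.0667 h in this assay, at which 1 of the 3 values shown sits. Against the two earlier groups, the change gives an at least 1.0-fold lower number from compound 2 to compound 3 (0.04 log units; that floor lies within the scatter) and an at least 1.4-fold lower number from compound 1 to compound 3 (0.16 log units; that floor lies within the scatter); both floors lie within the scatter, so neither step establishes a real difference, and the full size of each remains unknown. What compound 3 adds is that carbamoylmethyl, a group with no ring, does not lift the half-life clear of the values for the earlier groups on the saturated chain carbon bound to an aromatic carbon and a saturated chain carbon, so all three groups now sit at the short-lived end of the read-out.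

The compounds shown leave open how far the half-life of compound 3 lies past its limit, and so whether the replacement of (1,3-thiazol-2-yl)amino or 2-oxopiperidin-1-yl truly shortens it. They also leave open whether a different group at this place, such as a carboxylic acid or a simple amine, would give a half-life beyond the scatter from these three.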